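From 2-Bromophenyl to 4-Methoxyphenyl

The source may report more compounds than this note shows. Statements on the series, on what has been measured and on what is new or still open speak of the compounds shown alone.

In a functional assay on SW-620 cells (Homo sapiens) for cytotoxicity, read by MTT assay, with a stated time of 72 h (on this read-out higher numbers stand for weaker inhibition and lower numbers for stronger inhibition), compound 3 (`COc1ccc(/C=C2\CCC/C(=C\c3ccccc3Br)C2=O)cc1OC`) gives 5300 nM. Compound 2 (`COc1cccc(/C=C2\CCC/C(=C\c3cccc(OC)c3OC)C2=O)c1`) gives 7000 nM, which lies within the scatter of compound 3. Compound 1 (`COc1cccc(/C=C2\CCC/C(=C\c3ccc(Cl)cc3)C2=O)c1OC`) gives 11100 nM. The gap between compound 3 and compound 1 lies beyond the scatter, with compound 3 having the lower number. Compound 4 (`COc1ccc(/C=C2\CCC/C(=C\c3ccc(OC)c(OC)c3)C2=O)cc1`) has 4-methoxyphenyl in place of 2-bromophenyl on a double-bonded chain carbon bound to a double-bonded ring carbon. Going by the values given here, the only measured step that exchanges a group at this place, a 1.6-fold lower number from compound 1 to compound 2 (0.20 log units; within the scatter), stays within the scatter. Among the compounds with values here, no measured step tests the 2-bromophenyl group directly. No shift beyond the scatter is therefore expected, and the estimated change is a 1.2-fold higher number from compound 3 to compound 4 (0.09 log units; within the scatter). For compound 4 the expected value in this assay is 6500 nM, with an estimated range of 2500 nM to 16000 nM.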

Compound 4, half-maximal inhibitory concentration: 6600 nM
Beside the measured number, compound 4's estimate is 1.0-fold (0.01 log units) below it; the range from low to high includes it.
By their numbers in this assay, from the lowest: compounds 3, 4, 2 and 1 (each within the scatter of the next, the first and the last beyond it).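

In this assay, the exchange at this place gives a 1.2-fold higher number from compound 3 to compound 4 (0.10 log units; within the scatter) and so stays within the scatter. Going by these compounds alone, this step tests the 2-bromophenyl group directly, which no earlier step did, and shows that 4-methoxyphenyl can take its place on a double-bonded chain carbon bound to a double-bonded ring carbon without a shift beyond the scatter. Nothing at hand offers an explanation for this result. The compounds shown leave open whether an aromatic ring carrying an amine or a carboxylic acid, or a longer chain in place of the aromatic ring, would also stay within the scatter.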